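Changing the Aryl Group on the Sulfonyl Sulfur

The source may report more compounds than this note shows. Statements on the series, on what has been measured and on what is new or still open speak of the compounds shown alone.

Two compounds have been measured in a functional assay for antagonist activity at B1 bradykinin receptor (Mus musculus), using Schild analysis, with a stated time of 30 min; on this read-out lower numbers stand for lower potency and higher numbers for higher potency (the scale is a negative logarithm):

Compound 1 `COc1ccc(S(=O)(=O)N(C)CCOCC(=O)N(C)Cc2ccc(C3=NCCN3)cc2)c(C)c1`, which in this assay gives 6.9
Compound 2 `Cc1c(Cl)ccc(S(=O)(=O)N(C)CCOCC(=O)N(C)Cc2ccc(C3=NCCN3)cc2)c1Cl`, which in this assay gives 7.5

Compound 2 stands highest of these two numbers; the nearest is compound 1, and the gap is a number 0.60 log units higher from compound 1 to compound 2 (beyond the scatter). Compound 3 `CN(Cc1ccc(C2=NCCN2)cc1)C(=O)COCCN(C)S(=O)(=O)c1ccccc1C#N` is the next candidate. It differs from compound 2 in one place: 2-cyanophenyl in place of 2,4-dichloro-3-methylphenyl on a sulfonyl sulfur. Within the data shown here, the only measured step that bears on this change is a number 0.60 log units higher from compound 1 to compound 2 (beyond the scatter), which shows that swapping the aryl group at this position can shift potency by a modest amount. Among the measured compounds shown here, no measured pair includes the 2-cyanophenyl group, so its effect is not known from these data. Because compound 2 reached 7.5 with the 2,4-dichloro-3-methylphenyl group, a modest loss is expected on moving to the smaller group, a step of a number 0.70 log units lower from compound 2 to compound 3 (beyond the scatter). Compound 3 is therefore estimated at 6.8, within a range from 6 to 7.6.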

Compound 3, negative logarithm of the antagonist equilibrium constant: 6
The estimate for compound 3 lay 0.80 log units above the measured number; the measured number falls inside the stated range.
By their numbers in this assay, from the lowest: compound 3; then compound 1; then compound 2.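

Putting 2-cyanophenyl on the sulfonyl sulfur costs more than the earlier pair could show: in this assay the change gives a number 1.50 log units lower from compound 2 to compound 3 (beyond the scatter) as a large step and a number 0.90 log units lower from compound 1 to compound 3 (beyond the scatter) as a modest one. The aryl group at this place can therefore move potency both up and down from compound 1, and compound 3 is the least potent of the three. Nothing here gives a measured reason for the drop in compound 3.

Going by these compounds, the swap from 2,4-dichloro-3-methylphenyl removes both chlorine atoms and the methyl group and adds a nitrile in one move, so the share of each remains unknown. A plain phenyl or a 2-chlorophenyl group on the same sulfur would help to separate these parts.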